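The source may hold more compounds than are shown below. What is called first, only, known or untested is meant among the compounds shown, and "the series" means these compounds.

Measured compounds in an assay on Sf9 cells for inhibition of inhibitor of nuclear factor kappa-B kinase subunit epsilon (Homo sapiens), read by ADP-Glo, with a stated time of 60 min; a lower number here means a stronger inhibitor, a higher number a weaker inhibitor:
- compound 1 `CCC(=O)n1nc(C)c(-c2ccc(Cl)c(Cl)c2)c1N` gives > 100000 nM.
- compound 2 `CCCC(=O)n1nc(C)c(-c2ccc(Cl)c(Cl)c2)c1N` gives > 100000 nM.
- compound 3 `Cc1nn(C(=O)C2CCCC2)c(N)c1-c1ccc(Cl)c(Cl)c1` gives > 100000 nM.

Each of these three values is a limit of the assay, not a number. Compound 3 thus stands at the same limit as the other two members of the series: the limit of > 100000 nM in this assay, at which 3 of the 3 values shown sit. The steps among the measured compounds, a step that the two limits leave unreadable from compound 1 to compound 2, a step that the two limits leave unreadable from compound 1 to compound 3 and a step that the two limits leave unreadable from compound 2 to compound 3, are all of unreadable size, since both ends of each step sit at the limit.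

Compound 4 `Cc1nn(C)c(N)c1-c1ccc(Cl)c(Cl)c1` differs from compound 3 by methyl in place of cyclopentylcarbonyl on an aromatic nitrogen. Among the measured compounds shown here, none of the measured steps changes the group on the aromatic nitrogen in this way; the three acyl variants all leave the compounds at the limit, so no measured step bears on the change, and nothing points to a gain. The expectation for compound 4 is a step of a number no higher from compound 3 to compound 4 (the limit leaves the size open) of no readable size in this assay, with compound 4 most likely reported again only as a limit. Compound 4 is estimated at 100000 nM, within 20000 nM to 300000 nM.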

Compound 4, half-maximal inhibitory concentration: > 100000 nM
Compound 4 was reported as a limit; the forecaster's own chance of this, stated with the estimate: 80%; the middle value lies on the limit itself.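

The steps from compound 1, compound 2 and compound 3 to compound 4 cannot be read, since all four compounds stand at one assay limit, not a number: the limit of > 100000 nM in this assay, at which 4 of the 4 values shown sit.

The compounds shown leave open whether any group on that aromatic nitrogen of the shared core gives a measurable value.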